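Dipropargyl variant of a limit-bound propargylamine series

The source may hold more compounds than are shown below. What is called first, only, known or untested is meant among the compounds shown, and "the series" means these compounds.

Measured compounds in an assay on isolated protein for inhibition of Amine oxidase [flavin-containing] A (Homo sapiens), read by fluorescence and Amplex Red, with a stated time of 15 min; a lower number here means a stronger inhibitor, a higher number a weaker inhibitor:
compound 1 `C#CCN(CCC)Cc1cn(-c2cc(NC(=S)NCC)ncn2)cn1` gives > 50000 nM, a limit of this assay.
compound 2 `C#CCN(Cc1ccccc1)Cc1cn(-c2cc(NC(=S)NCC)ncn2)cn1` gives > 50000 nM, a limit of this assay.
compound 3 `C#CCN(CC#N)Cc1cn(-c2cc(NC(=S)NCC)ncn2)cn1` gives > 50000 nM, a limit of this assay.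

Compound 3 therefore stands at the assay limit, as do the two other compounds shown; this is the situation described by the limit of > 50000 nM in this assay, at which 3 of the 3 values shown sit. The steps a step that the two limits leave unreadable from compound 1 to compound 2, a step that the two limits leave unreadable from compound 1 to compound 3 and a step that the two limits leave unreadable from compound 2 to compound 3 are all unreadable, since each runs from one limit to another. Compound 4 `C#CCN(CC#C)Cc1cn(-c2cc(NC(=S)NCC)ncn2)cn1` differs from compound 3 by ethynyl in place of cyano on a saturated chain carbon bound to an amine nitrogen. The measured steps that bear on this change are exactly those three unreadable ones, so no size or direction can be drawn from them. Compound 4 is expected to stay at the limit, the estimated step that the limit leaves unreadable from compound 3 to compound 4 being unreadable as well. The estimated value for compound 4 is 70000 nM, within 20000 nM to 250000 nM.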

Compound 4, half-maximal inhibitory concentration: > 50000 nM
Compound 4 was reported as a limit; the forecaster's own chance of this, stated with the estimate: 85%; the middle value lies beyond the limit too.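

No step from compound 4 to compound 1, compound 2 or compound 3 can be read, because each runs between two limits: the limit of > 50000 nM in this assay, at which 4 of the 4 values shown sit.

The compounds shown leave open how strongly any of them acts in this assay, and whether changing this amine substituent alters that.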